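This account rests on a few compounds, and the source may have more. Where it says the series, first, only, none or still open, it means among the compounds named here.

Measured so far in a physicochemical assay for solubility; on this read-out lower numbers stand for lower solubility and higher numbers for higher solubility:

- compound 1 `Cc1nc(C)c(C(=O)NCC(=O)Oc2ccc(-c3cc(=O)c4c(O)c(O)c(O)cc4o3)cc2)nc1C`: 628 ug/mL
- compound 2 `Cc1nc(C)c(C(=O)N[C@@H](C(=O)Oc2ccc(-c3cc(=O)c4c(O)c(O)c(O)cc4o3)cc2)C(C)C)nc1C`: 240 ug/mL
- compound 3 `Cc1nc(C)c(COC(=O)NCC(=O)Oc2ccc(-c3cc(=O)c4c(O)c(O)c(O)cc4o3)cc2)nc1C`: 454 ug/mL

Compound 3 holds the second place of the three numbers, yet it lies within the usual scatter of both other compounds. Only compound 1 and compound 2 stand apart beyond that scatter.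

Compound 4 `Cc1nc(C)c(COC(=O)N[C@@H](C(=O)Oc2ccc(-c3cc(=O)c4c(O)c(O)c(O)cc4o3)cc2)C(C)C)nc1C` has not yet been measured. It differs from compound 3 by isopropyl in place of hydrogen on a saturated chain carbon bound to an amide-type nitrogen and a carbonyl carbon.

The same change has been measured once, a 2.6-fold lower number from compound 1 to compound 2 (0.42 log units; beyond the scatter), a modest step beyond the scatter. Within the data shown here, the other measured step, a 1.4-fold lower number from compound 1 to compound 3 (0.14 log units; within the scatter), stays within the scatter and shows only that compound 3 behaves much like compound 1. A similar modest fall is therefore expected in this assay, although it rests on a single pair. The expected change is a 2.6-fold lower number from compound 3 to compound 4 (0.41 log units; beyond the scatter). For compound 4 the estimated value is 175 ug/mL, with an expected range of 85 ug/mL to 360 ug/mL.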

Compound 4, solubility: 252 ug/mL
Estimate against measurement, compound 4: 1.4-fold (0.16 log units) below; low and high end bracket the measured number.
By their numbers in this assay, from the lowest: compounds 2, 4, 3 and 1 (each within the scatter of the next, the first and the last beyond it).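

In this assay isopropyl in place of hydrogen on a saturated chain carbon bound to an amide-type nitrogen and a carbonyl carbon gives a 1.8-fold lower number from compound 3 to compound 4 (0.26 log units; within the scatter) where the carbonyl carbon carries (3,5,6-trimethylpyrazin-2-yl)methoxy, against a 2.6-fold lower number from compound 1 to compound 2 (0.42 log units; beyond the scatter) where it carries 3,5,6-trimethylpyrazin-2-yl. The change thus lies within the scatter in one pair and beyond it in the other, so the second pair does not confirm the step seen in the first. The swap between those two groups, read with isopropyl present as a 1.1-fold higher number from compound 2 to compound 4 (0.02 log units; within the scatter) and with hydrogen present as a 1.4-fold lower number from compound 1 to compound 3 (0.14 log units; within the scatter) stays within the scatter in both pairs.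

The compounds shown leave open how a longer chain, an amine or a carboxylic acid would read on that saturated chain carbon. Nothing at hand accounts for the two isopropyl steps landing on different sides of the scatter.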